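A few compounds are considered here, and "the series" means these few. Any claim that something is new, unique, unknown or untested is made for them only; others in the source may bear on it.

Measured in a functional assay on RS4-11 cells (Homo sapiens) for inhibition, read by CCK-8 assay, with a stated time of 48 h, tested at 20 uM; a lower number here means less inhibition of growth, a higher number more inhibition of growth at the concentration tested:
- compound 1 `COc1ccc(S(=O)(=O)Oc2ccccc2/C=C(\C#N)C(=O)Nc2nnc(Cc3cccc4ccccc34)s2)cc1`: 78%
- compound 2 `COc1ccc(S(=O)(=O)Oc2ccccc2/C=C(\C#N)C(=O)Nc2nnc(Cc3ccccc3)s2)cc1`: 78%

Compound 2 reads 78%, level with compound 1, and these two values are all the series offers so far. The next structure is compound 3 `COc1ccc(S(=O)(=O)Oc2ccccc2/C=C(\C#N)C(=O)Nc2nnc(Cc3ccc(F)cc3)s2)cc1`, with the change fluoro in place of hydrogen on an aromatic carbon, para to a large group. Put another way, benzyl goes to 4-fluorobenzyl.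

Among the compounds with values here, only one measured step bears on this. It is no change at the digits printed from compound 1 to compound 2 (within the scatter), with phenyl in place of naphthalen-1-yl on a saturated chain carbon bound to an aromatic carbon. One step is thin evidence, but it gives no reason to expect movement from the smaller change here. The step expected in this assay is a number 1 percentage points lower from compound 2 to compound 3 (within the scatter), so nothing beyond the scatter is anticipated. For compound 3 the estimated value is 77%, with an expected range of 66% to 88%.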

Compound 3, percent growth inhibition at one concentration: 76%
Beside the measured number, compound 3's estimate is 1 percentage points above it; low and high end bracket the measured number.
By their numbers in this assay, from the lowest: compounds 3, 1 and 2 (each within the scatter of the next).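

In this assay fluoro in place of hydrogen on an aromatic carbon, para to a large group, gives a number 2 percentage points lower from compound 2 to compound 3 (within the scatter) and is the first substitution shown on the ring of the benzyl group, since the earlier pair only exchanged one ring system for another. Taking 4-fluorophenyl in place of naphthalen-1-yl gives a number 2 percentage points lower from compound 1 to compound 3 (within the scatter) and so extends the earlier result: all three groups on this saturated chain carbon now read alike within the scatter. The data available offer no explanation for this flat reading.

From the compounds shown here alone, whether an amine or a carboxylic acid in place of the fluoro, or a longer chain in place of the benzyl group, would separate from these values stays open. Going by these compounds, all readings come from a single concentration, so any differences in potency that this one concentration does not resolve also stay open.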